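A few compounds are considered here, and "the series" means these few. Any claim that something is new, unique, unknown or untested is made for them only; others in the source may bear on it.

Compound 1 `Cc1ccc2[nH]c(C(=O)N[C@H]3CN(S(=O)(=O)c4ccccc4)C[C@@H]3C(=O)N[C@H]3CCCN(C)C3)cc2c1` and compound 2 `Cc1ccc2[nH]c(C(=O)N[C@H]3CN(S(=O)(=O)c4ccccc4)C[C@@H]3C(=O)N[C@H]3CCCNC3)cc2c1` share one core. In a functional assay on HEK293 cells for agonist activity at growth hormone secretagogue receptor type 1 (Homo sapiens), read by HTRF and inositol phosphate accumulation, with a stated time of 90 min, in the presence of a further agent that is not named here (a lower number here means a smaller maximal response, a higher number a larger maximal response), compound 1 gives 99%, and compound 2 gives 98%. Between them stands (hydrogen in place of methyl on an amine nitrogen in a ring), which made a step of a number 1 percentage points lower from compound 1 to compound 2 (within the scatter). Compound 3 `Cc1ccc2[nH]c(C(=O)N[C@H]3CCN(S(=O)(=O)c4ccccc4Cl)C[C@@H]3C(=O)N[C@H]3CCCN(C)C3)cc2c1` carries another core; the difference between the two cores is not broken down here. In this assay compound 3 gives 107%, a value within the scatter of both compound 1 and compound 2. Compound 4 `Cc1ccc2[nH]c(C(=O)N[C@H]3CCN(S(=O)(=O)c4ccccc4Cl)C[C@@H]3C(=O)N[C@H]3CCCNC3)cc2c1` has not yet been measured; it differs from compound 3 by hydrogen in place of methyl on an amine nitrogen in a ring, the same change as that from compound 1 to compound 2. Because that change earlier gave a number 1 percentage points lower from compound 1 to compound 2 (within the scatter), the step expected for compound 4 is a number 2 percentage points lower from compound 3 to compound 4 (within the scatter). The estimate for compound 4 in this assay is 105%, expected to fall between 95% and 115%.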

Compound 4, largest response reached (Emax), in percent of the reference or control that the assay uses in the growth hormone secretagogue receptor type 1 assay: 97%
Compound 4: middle estimate off by 8 percentage points, on the high side; measured number inside the range.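

In the growth hormone secretagogue receptor type 1 assay, the replacement of methyl by hydrogen gave a number 10 percentage points lower from compound 3 to compound 4 (within the scatter), and the step on this core does not differ from the earlier one: the same change on two cores in the growth hormone secretagogue receptor type 1 assay, a number 1 percentage points lower (within the scatter) from compound 1 to compound 2 and a number 10 percentage points lower (within the scatter) from compound 3 to compound 4, 9 percentage points apart, within the scatter of two such steps So in these two pairs the change carries from one core to the other without a step beyond the scatter in maximal response, though two pairs establish no general rule. In a physicochemical assay for lipophilicity, measured as octanol-water partition, at pH 7.4 (a higher number here means a more lipophilic compound, a lower number a more polar compound), compound 3 gives 3.1 and compound 4 gives 1.9, but this shift is shown on the core of compound 3 alone, and whether it carries to the core of compound 1 remains unknown.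

The compounds shown leave open how larger groups on the same ring nitrogen, such as an ethyl or an acetyl group, would behave in the growth hormone secretagogue receptor type 1 assay.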